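The source may hold more compounds than are shown below. What is called first, only, known or untested is meant among the compounds shown, and "the series" means these compounds.

Compound 1 `CS(=O)(=O)CCCn1c(Cn2c(=O)n(CC#N)c3ccncc32)cc2cc(Cl)ccc21` is the starting point of this short series. In an ADME assay on HeLa cells (Homo sapiens) for cytotoxicity, read by ATP content, with a stated time of 3 days (on this read-out higher numbers stand for lower toxicity in this test and lower numbers for higher toxicity in this test), compound 1 shows only a limit of the assay, > 50000 nM. Compound 2 `CC1(n2c(=O)n(Cc3cc4cc(Cl)ccc4n3CCCS(C)(=O)=O)c3cnccc32)CC1` carries 1-methylcyclopropyl in place of cyanomethyl on an aromatic nitrogen. In this assay compound 2 likewise gives only a limit of the assay, > 50000 nM. The step that the two limits leave unreadable from compound 1 to compound 2 is therefore not readable, since both values are limits. Where compound 2 stands is thus described by the limit of > 50000 nM in this assay, at which 2 of the 2 values shown sit. Compound 3 `CS(=O)(=O)CCCn1c(Cn2c(=O)n(C3COC3)c3ccncc32)cc2cc(Cl)ccc21` is not yet measured; it differs from compound 2 by oxetan-3-yl in place of 1-methylcyclopropyl on an aromatic nitrogen. Among the measured compounds shown here, no measured step reads out a size here, and no step runs beyond the scatter in a known direction. The expectation is that the step from compound 2 to compound 3 is a number no higher from compound 2 to compound 3 (the limit leaves the size open), that is, none beyond the scatter, with the outcome most likely again a limit. For compound 3 the estimated value is 50000 nM, within a range from 20000 nM to 100000 nM.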

Compound 3, half-maximal cytotoxic concentration: > 50000 nM
Compound 3 ended at the assay's limit; the forecaster's own chance of this, stated with the estimate: 85%; the middle value sits exactly at the limit.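

Compound 1, compound 2 and compound 3 all stop at a limit of this assay, so no step among them can be read: the limit of > 50000 nM in this assay, at which 3 of the 3 values shown sit.

The compounds shown leave open whether any group on this aromatic nitrogen would give a number rather than a limit in this assay.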